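A few compounds are considered here, and "the series" means these few. Any claim that something is new, unique, unknown or untested is made for them only; others in the source may bear on it.

Series notes. Compound 1 `OC1CC2(N3CCCC3)CC(c3ccc(Cl)cc3)C1C(c1ccc(Cl)cc1)C2` gives 3590 nM in an ADME assay on L6 cells (Rattus norvegicus) for cytotoxicity; on this read-out lower numbers stand for stronger inhibition and higher numbers for weaker inhibition. Compound 2 `OC1CC2(N3CCCCC3)CC(c3ccc(Cl)cc3)C1C(c1ccc(Cl)cc1)C2` gives 11600 nM in this assay; the change piperidin-1-yl in place of pyrrolidin-1-yl on a saturated ring carbon made a step of a 3.2-fold higher number from compound 1 to compound 2 (0.51 log units; beyond the scatter). Compound 3 `O/N=C1\CC2(N3CCCC3)CC(c3ccccc3)C1C(c1ccccc1)C2` gives 13500 nM in this assay; the difference between the core of compound 3 and the core of compound 1 is not broken down here. Compound 4 `O/N=C1\CC2(N3CCCCC3)CC(c3ccccc3)C1C(c1ccccc1)C2` awaits measurement. Within the data shown here, it differs from compound 3 by piperidin-1-yl in place of pyrrolidin-1-yl on a saturated ring carbon, the same kind of change as the one between compound 1 and compound 2, though the surroundings differ: here the ring atom two ring bonds away bears a phenyl group, whereas in compound 1 it bears a 4-chlorophenyl group and a further ring atom bears a hydroxy group. In this assay, among the measured compounds shown here, a step of about a 2.6-fold higher number from compound 3 to compound 4 (0.41 log units; beyond the scatter) is expected, resting on the single earlier step of a 3.2-fold higher number from compound 1 to compound 2 (0.51 log units; beyond the scatter) carried over to compound 3 at 13500 nM. Compound 4 is therefore estimated near 35000 nM, with a range from 14000 nM to 90000 nM.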

Compound 4, half-maximal inhibitory concentration: 24200 nM
Compound 4: middle estimate off by 1.4-fold (0.16 log units), on the high side; low and high end bracket the measured number.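

In this assay, piperidin-1-yl in place of pyrrolidin-1-yl on the core of compound 3 gives a 1.8-fold higher number from compound 3 to compound 4 (0.25 log units; within the scatter), a step that cannot be told apart from repeat measurements on its own. Set beside the earlier step, it shows no difference between the two cores: the same change on two cores in this assay, a 3.2-fold higher number (0.51 log units; beyond the scatter) from compound 1 to compound 2 and a 1.8-fold higher number (0.25 log units; within the scatter) from compound 3 to compound 4, 1.8-fold (0.26 log units) apart, within the scatter of two such steps. This fits the change carrying over from one core to the other, but two pairs do not fix a common step size, and the two cores differ in several places, so the contribution of each difference to the step cannot be read.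

On these data alone, whether the step holds for other amines on the same saturated ring carbon, such as morpholin-4-yl or an open-chain dimethylamino group, stays open. The same applies to cores other than these two.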